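Adding a Second Ethyl Group to an Amide Nitrogen

The source may hold more compounds than are shown below. What is called first, only, known or untested is meant among the compounds shown, and "the series" means these compounds.

Measured compounds:
Compound 1 `CC1=C(C(=O)OC(C)(C)C)C(c2ccsc2)NC(=O)N1` gives 47% in an assay on membranes from HEK293 cells for displacement of a labelled ligand from adenosine receptor A2b (Homo sapiens), read by scintillation counting, with a stated time of 30 min, tested at 1 uM; on this read-out lower numbers stand for less inhibition and higher numbers for more inhibition at the one concentration tested (going by the name of the read-out).
Compound 2 `CCNC(=O)C1=C(C)NC(=O)NC1c1ccsc1` gives 1% in this assay.

Compound 2 stands lowest of the two numbers. Among the measured compounds shown here, its nearest neighbour is compound 1, and the one measured step, a number 46 percentage points lower from compound 1 to compound 2 (beyond the scatter), arises when ethylamino replaces tert-butoxy on the carbonyl carbon.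

Compound 3 `CCN(CC)C(=O)C1=C(C)NC(=O)NC1c1ccsc1` has not been measured. It differs from compound 2 by ethyl in place of hydrogen on an amide-type nitrogen. For the measured compounds named here, no measured step concerns an ethyl entering an amide-type nitrogen; the only known step covers a different change at the carbonyl, so it offers little guidance here. With compound 2 already near the floor of the read-out, a further fall cannot be large, and any rise is unsupported. Compound 3 is therefore expected to show a step of a number 7 percentage points higher from compound 2 to compound 3 (within the scatter) in this assay, within the scatter. The estimate for compound 3 is 8%, with a range from 0% to 30%.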

Compound 3, a percentage reported as inhibition, at one concentration (the size of the read-out at that concentration, not a potency): 11%
Compound 3: middle estimate off by 3 percentage points, on the low side, and the stated range covers the measured number.
By their numbers in this assay, from the lowest: compounds 2 and 3 (each within the scatter of the next); then compound 1.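

In this assay, ethyl in place of hydrogen on the amide-type nitrogen gives a number 10 percentage points higher from compound 2 to compound 3 (within the scatter) and so does not separate ethylamino from diethylamino at this position. Diethylamino in place of tert-butoxy on the carbonyl carbon gives a number 36 percentage points lower from compound 1 to compound 3 (beyond the scatter) as its step, so the fall seen with ethylamino also appears with a second amide and is not limited to that single group. Nothing available here explains either result.

Still open, on these data alone, is whether a longer chain on this nitrogen, such as propyl or butyl, would leave the number as low as in these two amides. As far as these compounds go, it is also open whether a smaller ester, such as the methyl ester, would come closer to compound 1 or to the amides.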